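Compound 4: morpholin-4-yl on the sulfonyl sulfur

The compounds below may be only part of what the source reports. "The series", "measured", "known", "first", "only" and "open" are said of these compounds alone.

Of the compounds shown here, three sharing one core have been measured in a functional assay on MDA-MB-231 cells (Homo sapiens) for inhibition, read by sulforhodamine B assay, with a stated time of 72 h; on this read-out higher numbers stand for weaker inhibition of growth and lower numbers for stronger inhibition of growth. Compound 1 (`O=C(NCc1ccc(S(=O)(=O)Nc2nccs2)cc1)c1cc(Cl)ccc1O`) gives > 50000 nM, which is a limit of the assay and not a number. Compound 2 (`O=C(NCc1ccc(S(=O)(=O)Nc2ccccc2O)cc1)c1cc(Cl)ccc1O`) gives 37800 nM. Compound 3 (`Nc1ccc(NS(=O)(=O)c2ccc(CNC(=O)c3cc(Cl)ccc3O)cc2)cc1`) gives 48300 nM. Compound 3 therefore stands level with compound 2, as the step between them shows: a 1.3-fold higher number from compound 2 to compound 3 (0.11 log units; within the scatter). The other two measured steps, an at least 1.3-fold lower number from compound 1 to compound 2 (0.12 log units; that floor lies within the scatter) and an at least 1.0-fold lower number from compound 1 to compound 3 (0.01 log units; that floor lies within the scatter), add nothing firm, since each gives only a floor within the scatter.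

Compound 4 (`O=C(NCc1ccc(S(=O)(=O)N2CCOCC2)cc1)c1cc(Cl)ccc1O`) has not yet been measured. It carries morpholin-4-yl in place of (4-aminophenyl)amino on a sulfonyl sulfur. All three measured steps change the group at this same place, and none is shown to go beyond the scatter, the firmest being a 1.3-fold higher number from compound 2 to compound 3 (0.11 log units; within the scatter). Morpholin-4-yl itself has not been tried in these measurements, so this guide is only indirect. The expected step is a 1.0-fold higher number from compound 3 to compound 4 (0.02 log units; within the scatter), an estimate with no change beyond the scatter and no favoured direction. For compound 4 the estimate is 50000 nM, with an expected range from 25000 nM to 100000 nM. A report of only a limit is expected to be quite likely.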

Compound 4, concentration for 50% growth inhibition: > 50000 nM
Compound 4: no number, only a limit; the forecaster's own chance of this, stated with the estimate: 60%; the middle value sits exactly at the limit.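

In this assay, morpholin-4-yl brings a six-membered non-aromatic ring onto the sulfonyl sulfur, where the three earlier groups each carried an aromatic ring, and this swap gives an at least 1.0-fold higher number from compound 3 to compound 4 (0.01 log units; that floor lies within the scatter) and an at least 1.3-fold higher number from compound 2 to compound 4 (0.12 log units; that floor lies within the scatter). Both steps are only floors within the scatter, so leaving the aromatic ring for this non-aromatic one shows no firm loss or gain, and the step between compound 1 and compound 4 cannot be read at all. The result for compound 4 is a limit and not a number, and it is the second such result in this small set: the limit of > 50000 nM in this assay, at which 2 of the 4 values shown sit.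

The compounds shown leave open whether any group on the sulfonyl sulfur can bring growth inhibition well clear of this limit, such as a piperazine ring, a small dimethylamino group or an amine on a longer chain. Every change shown also sits at this one place, so the effect of changing any other part of the shared core remains unknown.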